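The compounds below may be only part of what the source reports. "The series", "measured", "known", "first", "only" and "open" are said of these compounds alone.

The measured compounds and their values in a functional assay on A549 cells (Homo sapiens) for inhibition, read by MTT assay, with a stated time of 48 h; a lower number here means a stronger inhibitor, a higher number a weaker inhibitor:

Compound 1, `COc1ccc(/C=C/c2cc(OC)cc(OC)c2/C=C/C(=O)Nc2cc(OC)c(OC)c(OC)c2)cc1`: 5140 nM
Compound 2, `COc1ccc(/C=C/c2cc(OC)cc(OC)c2/C=C/C(=O)NC2CC2)cc1`: 8810 nM
Compound 3, `COc1ccc(/C=C/c2cc(OC)cc(OC)c2/C=C/C(=O)N2CCCCC2)cc1`: 10600 nM

Compound 2 stands second highest of the three numbers in this assay. Its nearest neighbour is compound 3, with a 1.2-fold higher number from compound 2 to compound 3 (0.08 log units; within the scatter); its furthest is compound 1, with a 1.7-fold higher number from compound 1 to compound 2 (0.23 log units; within the scatter). All three compounds share the same core and differ only in the group carried on the amide nitrogen, and neither of the measured steps leaves the scatter.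

The next compound, compound 4, `CCCCCCCCNC(=O)/C=C/c1c(/C=C/c2ccc(OC)cc2)cc(OC)cc1OC`, follows the same line. Its difference from compound 2: octyl in place of cyclopropyl on an amide-type nitrogen. Both measured steps bear on this change, since each of them also swaps the group on the amide-type nitrogen, and both were within the scatter. On that basis a step in this assay beyond the scatter is not expected in either direction for compound 4. Compound 4 is therefore estimated at 9000 nM, within 4000 nM to 20000 nM. The expected step from compound 2 is a 1.0-fold higher number from compound 2 to compound 4 (0.01 log units; within the scatter).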

Compound 4, half-maximal inhibitory concentration: 8660 nM
For compound 4 the middle estimate is 1.0-fold (0.02 log units) above the measured one; low and high end bracket the measured number.
By their numbers in this assay, from the lowest: compounds 1, 4, 2 and 3 (each within the scatter of the next, the first and the last beyond it).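

Among the compounds shown, only compound 4 carries an open chain on the amide-type nitrogen, and in this position in (this assay) the change from cyclopropyl to octyl gives no step beyond the scatter (a 1.0-fold lower number from compound 2 to compound 4 (0.01 log units; within the scatter)). The same holds where octylamino takes the place of piperidin-1-yl (a 1.2-fold lower number from compound 3 to compound 4 (0.09 log units; within the scatter)) and where octyl takes the place of 3,4,5-trimethoxyphenyl (a 1.7-fold higher number from compound 1 to compound 4 (0.23 log units; within the scatter)). An open chain of eight carbons is therefore not told apart here from any of the three earlier groups, although compounds 1 and 3 do lie beyond the scatter of each other.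

Going by these compounds, whether a longer chain, an amine or a carboxylic acid on this nitrogen would give a step beyond the scatter remains open. Nothing measured here offers an explanation for these results.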